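This account rests on a few compounds, and the source may have more. Where it says the series, first, only, none or still open, it means among the compounds named here.

Measured compounds:
compound 1 `COc1ccc(S(=O)(=O)N2CCc3cccc(-c4ccc([N+](=O)[O-])cc4)c32)cc1` — 52.5 nM
compound 2 `COc1ccc(S(=O)(=O)N2CCc3cccc(-c4ccccc4)c32)cc1` — 120 nM
compound 3 `COc1ccc(S(=O)(=O)N2CCc3cccc(-c4ccc(C#N)cc4)c32)cc1` — 31.1 nM

In a functional assay on KB cells (Homo sapiens) for inhibition, with a stated time of 72 h (on this read-out higher numbers stand for weaker inhibition and lower numbers for stronger inhibition), compound 1 gives 52.5 nM, the second highest of the three numbers shown. Compound 3 sits nearest, a 1.7-fold lower number from compound 1 to compound 3 (0.23 log units; within the scatter), whereas compound 2 lies furthest, a 2.3-fold higher number from compound 1 to compound 2 (0.36 log units; beyond the scatter). Compound 4 `COc1ccc(S(=O)(=O)N2CCc3cccc(-c4cccs4)c32)cc1` has not yet been measured; it differs from compound 1 in one place: thiophen-2-yl in place of 4-nitrophenyl on an aromatic carbon. The step that bears most on this change is the removal of the nitro group, a 2.3-fold higher number from compound 1 to compound 2 (0.36 log units; beyond the scatter); compound 4 likewise carries no nitro group. The step of a 3.9-fold lower number from compound 2 to compound 3 (0.59 log units; beyond the scatter) runs the same way, a substituent on that ring giving the lower number. A modest rise in the number is therefore expected for compound 4, a 1.9-fold higher number from compound 1 to compound 4 (0.28 log units; within the scatter). Compound 4 is estimated at 100 nM, within 40 nM to 250 nM.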

Compound 4, half-maximal inhibitory concentration: 215 nM
Compound 4: middle estimate off by 2.2-fold (0.33 log units), on the low side; measured number inside the range.
By their numbers in this assay, from the lowest: compounds 3 and 1 (each within the scatter of the next); then compounds 2 and 4 (each within the scatter of the next).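

In this assay, thiophen-2-yl on this aromatic carbon gives clearly higher numbers than either 4-nitrophenyl (a 4.1-fold higher number from compound 1 to compound 4 (0.61 log units; beyond the scatter)) or 4-cyanophenyl (a 6.9-fold higher number from compound 3 to compound 4 (0.84 log units; beyond the scatter)). Against plain phenyl the step stays within the scatter (a 1.8-fold higher number from compound 2 to compound 4 (0.25 log units; within the scatter)), so this five-membered aromatic ring and the unsubstituted six-membered ring cannot be told apart here. No evidence at hand accounts for these differences. Going by these compounds, it remains open whether a thiophene bearing a nitrile would recover the lower numbers, and how a pyridine ring or an aminophenyl group would fare at this position.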